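The compounds below may be only part of what the source reports. "The series", "measured", "known", "first", "only" and "open" are said of these compounds alone.

Measured so far:
compound 1, `COc1ccc(-c2nc(C)c(C(=O)CSc3nc(-c4cccc(OC)c4)c(C#N)c(=O)[nH]3)s2)cc1`, 71.3%;
compound 2, `Cc1nc(-c2ccccc2)sc1C(=O)CSc1nc(-c2cccc(Cl)c2)c(C#N)c(=O)[nH]1`, 86.9%;
compound 3, `COc1ccc(-c2nc(C)c(C(=O)CSc3nc(-c4ccccc4)c(C#N)c(=O)[nH]3)s2)cc1`, 99%.

In a functional assay on U-87MG ATCC cells for antiproliferative activity against U-87 MG (Homo sapiens), read by MTT assay, with a stated time of 48 h, tested at 5 uM (a higher number here means a weaker effect of the compound at the concentration tested, a lower number a stronger effect), compound 3 stands highest of the three, meaning its effect at the tested concentration is the weakest; compound 2 lies nearer to it and compound 1 furthest from it, both differences beyond the usual scatter.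

Compound 4, `COc1ccc(-c2nc(C)c(C(=O)CSc3nc(-c4cccc(Cl)c4)c(C#N)c(=O)[nH]3)s2)cc1`, is not yet measured. It differs from compound 3 in one place: chloro in place of hydrogen on an aromatic carbon. The same spot is where compound 3 and compound 1 differ, and that step, a number 27.7 percentage points higher from compound 1 to compound 3 (beyond the scatter), shows that putting a group there instead of hydrogen goes with a markedly lower number. Within the data shown here, compound 2 carries the same chloro group on the same ring but lacks the methoxy elsewhere, so no single step joins it to compound 4; its value and that of compound 3 show only that the chloro-bearing compound sits lower. From this, compound 4 is expected to fall below compound 3 by a modest amount, a number 19 percentage points lower from compound 3 to compound 4 (beyond the scatter), most likely beyond the scatter. The estimate for compound 4 in this assay is 80%, within a range from 62% to 96%.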

Compound 4, a percentage reported as activity, at one concentration (the size of the read-out at that concentration, not a potency): 95.7%
Estimate against measurement, compound 4: 15.7 percentage points below; the measured number falls inside the stated range.
By their numbers in this assay, from the lowest: compound 1; then compounds 2, 4 and 3 (each within the scatter of the next, the first and the last beyond it).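

On the ring that changes, chloro in place of hydrogen gives a number 3.3 percentage points lower from compound 3 to compound 4 (within the scatter) in this assay, while chloro in place of methoxy gives a number 24.4 percentage points higher from compound 1 to compound 4 (beyond the scatter), so among the groups shown at this place, only the methoxy of compound 1 goes with a stronger effect, and a group in place of hydrogen does not by itself lower the number. Methoxy in place of hydrogen elsewhere in the molecule, with the chloro kept, gives a number 8.8 percentage points higher from compound 2 to compound 4 (within the scatter), so that change shows no effect that can be told from scatter. Swapping methoxy for hydrogen therefore does not read the same in every case, and the earlier step cannot be taken as a general rule for this change: the same change on two cores in this assay, a number 27.7 percentage points higher (beyond the scatter) from compound 1 to compound 3 and a number 8.8 percentage points lower (within the scatter) from compound 4 to compound 2, 36.5 percentage points apart, beyond the scatter of two such steps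

With only hydrogen, chloro and methoxy shown on this ring, it remains open whether an ethoxy group, an amine or a carboxylic acid at the same place would match compound 1 or fall with compound 4. Each value is also a read-out at a single concentration, so these compounds give no potency, and a second methoxy-bearing compound would be needed to show how far the result for compound 1 holds.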